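Swapping Methoxy for Chloro on the Amide Arm

The source may report more compounds than this note shows. Statements on the series, on what has been measured and on what is new or still open speak of the compounds shown alone.

Of the compounds shown here, three sharing a trimethoxyphenyl-bearing core have been measured in a functional assay on MGC-803 cells (Homo sapiens) for inhibition, read by MTT assay, with a stated time of 48 h; a lower number here means a stronger inhibitor, a higher number a weaker inhibitor. Compound 2 `COCC(=O)N(Cc1ccc(OC)c(O)c1)c1cc(OC)c(OC)c(OC)c1` gives 79 nM. Compound 3 `COC(=O)c1cc(CNc2cc(OC)c(OC)c(OC)c2)ccc1OC` gives 49600 nM. Compound 1 `COc1cc(NCc2ccccc2)cc(OC)c1OC` gives only a limit of the assay, > 80000 nM, not a number; the line the limit of > 80000 nM in this assay, at which 1 of the 3 values shown sits, records that one of the three values sits at this limit. Among the numbers shown, compound 2 stands lowest, and its nearest neighbour, compound 3, sits far higher, well beyond the usual scatter of this assay.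

Compound 4 `COc1ccc(CN(C(=O)CCl)c2cc(OC)c(OC)c(OC)c2)cc1O` has not yet been measured. It differs from compound 2 in one place: chloro in place of methoxy on a saturated chain carbon bound to a carbonyl carbon. Among the measured compounds shown here, no measured pair in this set differs by the same change, so the size of this step cannot be read from other compounds. Since compound 2 gives 79 nM and the change is small, the step from compound 2 to compound 4 is expected to stay within the scatter, with the estimated step of a 1.3-fold lower number from compound 2 to compound 4 (0.12 log units; within the scatter). Compound 4 is therefore estimated at 60 nM, with a range from 20 nM to 200 nM.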

Compound 4, half-maximal inhibitory concentration: 84 nM
For compound 4 the middle estimate is 1.4-fold (0.15 log units) below the measured one; low and high end bracket the measured number.
By their numbers in this assay, from the lowest: compounds 2 and 4 (each within the scatter of the next); then compound 3. At a limit, above all of these: compound 1.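

In this assay, among the compounds shown here, the first measured step at this position is a 1.1-fold higher number from compound 2 to compound 4 (0.03 log units; within the scatter). The swap removes methoxy, with its 2 heavy atoms and 1 hydrogen-bond acceptor, and puts in chloro, with 1 heavy atom and no hydrogen-bond acceptor, yet the two compounds cannot be told apart in this assay, so this place tolerates at least this one exchange. Nothing measured in this set explains why the two compounds read alike.

Going by these compounds, whether an amine, a carboxylic acid or a longer chain on this saturated chain carbon would also leave the number in the same range remains open. Compound 1 and compound 3 differ from compound 2 in more than one place, so they cannot settle that question.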